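Amide aryl variation: from compound 2 to compound 3

The source may hold more compounds than are shown below. What is called first, only, known or untested is meant among the compounds shown, and "the series" means these compounds.

compound 1 `CS(=O)(=O)c1ccc(C(=O)Nc2ccc(Cl)c(-c3nnc4c(Cl)cccn34)c2)c(Cl)c1`: 37200 nM
compound 2 `O=C(Nc1ccc(Cl)c(-c2nnc3c(Cl)cccn23)c1)c1cccc(Cl)c1`: 66100 nM

Of the compounds shown here, two have been measured in a functional assay on MDA-MB-231 cells (Homo sapiens) for antiproliferative activity, read by MTT assay, with stated times of 72 h and 4 h; on this read-out lower numbers stand for stronger inhibition and higher numbers for weaker inhibition. In this assay compound 1 gives 37200 nM and compound 2 gives 66100 nM. Compound 2 holds the higher of the two numbers, but its gap to compound 1 lies within the usual scatter, so the two readings are not distinguishable. Both sit in a weak range.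

Compound 3 `O=C(Nc1ccc(Cl)c(-c2nnc3c(Cl)cccn23)c1)c1ccc(Cl)cc1Cl` differs from compound 2 in one place: 2,4-dichlorophenyl in place of 3-chlorophenyl on a carbonyl carbon. Among the measured compounds shown here, no measured step covers this change, so nothing in the two readings points in either direction. The step is expected to be none beyond the scatter, a 1.3-fold lower number from compound 2 to compound 3 (0.12 log units; within the scatter), since both measured compounds already cluster in the same weak range. For compound 3 the value in this assay is estimated at 50000 nM, with a range from 15000 nM to 150000 nM; a reading reported only as a limit is possible.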

Compound 3, half-maximal inhibitory concentration: > 100000 nM
Compound 3 ended at the assay's limit (the forecaster's own chance of this, stated with the estimate: 20%); at least 2.0-fold (0.30 log units) between middle value and limit.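

In this assay compound 3 gives > 100000 nM, which is a limit of the assay and not a number, so its steps have a floor but no measured size: the limit of > 100000 nM in this assay, at which 1 of the 3 values shown sits. With 2,4-dichlorophenyl in place of 3-chlorophenyl on a carbonyl carbon, the reading shows an at least 1.5-fold higher number from compound 2 to compound 3 (0.17 log units; that floor lies within the scatter), so this change shows no gain, and any loss cannot be established. Chloro in place of methylsulfonyl on an aromatic carbon gives an at least 2.6-fold higher number from compound 1 to compound 3 (0.42 log units; beyond the scatter), the first step in the series to clear the scatter, and it points to the methylsulfonyl-bearing compound 1 as the better of this pair.

Going by these compounds, whether an amine or a carboxylic acid at that aromatic carbon would move the number in either direction stays open. Also open, on these data alone, is whether any amide aryl group on the shared core leaves the weak range.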